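The compounds below may be only part of what the source reports. "The series", "measured", "known", "first", "only" and "open" are said of these compounds alone.

Measured compounds:

Compound 1 `CC(C)N(Cc1cccc(OCCCCCC(=O)O)c1)C(=O)c1ccc(-c2cccc(-c3ccccc3)c2)cc1`: in an ADME assay on HepG2 cells (Homo sapiens) for cytotoxicity, read by CellTiter-Glo and resazurin assay, with a stated time of 72 h (a higher number here means that more compound is needed for the effect, a lower number that less compound is needed), compound 1 gives > 26000 nM, which is a limit of the assay and not a number.

Compound 2 `CC(C)N(Cc1cccc(OCCCCCC(=O)O)c1)C(=O)c1ccc(-c2cccc(Br)c2)cc1`: in this assay compound 2 gives > 26000 nM, again a limit rather than a number.

Compound 3 `CCOC(=O)CCCCCOc1cccc(CN(C(=O)c2ccc(-c3cccc(-c4ccccc4)c3)cc2)C(C)C)c1`: in this assay compound 3 gives > 26000 nM, also a limit and not a number.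

Compound 3 therefore stands at the same limit as the other two members of the series; none of the three values is a number, so no order among them can be read, and compound 3 cannot be called more or less cytotoxic than compound 1 or compound 2.

The step to compound 4 `CCOC(=O)CCCCCOc1cccc(CN(C(=O)c2ccc(-c3cccc(O)c3)cc2)C(C)C)c1` is hydroxy in place of phenyl on an aromatic carbon.

Within the data shown here, two measured steps touch the same region or the same series. The step that the two limits leave unreadable from compound 1 to compound 2 changed the outer ring in the same way as the present change leaves phenyl, and the step that the two limits leave unreadable from compound 1 to compound 3 gave compound 3 its ester. Both are unreadable in size because of the limit of > 26000 nM in this assay, at which 3 of the 3 values shown sit. No readable step in this assay exists anywhere in the series.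

Compound 4 is accordingly expected to sit where the series sits, with an expected step that the limit leaves unreadable from compound 3 to compound 4 that is nothing beyond the scatter. The estimate for compound 4 is 35000 nM, within 15000 nM to 100000 nM, most likely reported as a limit only.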

Compound 4, half-maximal effective concentration: > 26000 nM
Compound 4: only a limit was reported; the forecaster's own chance of this, stated with the estimate: 80%; the middle value is on the limit's open side.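

No step can be read from compound 3 to compound 4 in this assay because both values are limits and not numbers: the limit of > 26000 nM in this assay, at which 4 of the 4 values shown sit.

The compounds shown leave open whether any member of the series has a numerical half-maximal effective concentration, and whether hydroxy and phenyl differ at all here.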